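The source may report more compounds than this note shows. Statements on the series, on what has been measured and on what is new or still open speak of the compounds shown alone.

Compound 1 `COc1cc(/C=C/C(=O)C2=C(/C=C/c3ccc(O)c(OC)c3)NC(=O)NC2c2ccccc2)ccc1O`: 25000 nM
Compound 2 `COc1cc(/C=C/C(=O)C2=C(/C=C/c3ccc(O)c(OC)c3)NC(=O)NC2c2ccccc2O)ccc1O`: 100000 nM

In a functional assay on HCT-116 cells (Homo sapiens) for cytotoxicity, read by MTT assay, with a stated time of 48 h (on this read-out lower numbers stand for stronger inhibition and higher numbers for weaker inhibition), compound 2 gives 100000 nM, the higher of the two numbers and so the weaker inhibition, while compound 1 gives 25000 nM. The next compound to be tested is compound 3 `COc1cc(/C=C/C(=O)C2=C(/C=C/c3ccc(O)c(OC)c3)NC(=O)NC2c2ccc(N(C)C)cc2)ccc1O`. The structural change is 4-(dimethylamino)phenyl in place of 2-hydroxyphenyl on a saturated ring carbon.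

Among the measured compounds shown here, only one measured step bears on this change: a 4.0-fold higher number from compound 1 to compound 2 (0.60 log units; beyond the scatter), a modest step beyond the scatter that comes with hydroxy in place of hydrogen on an aromatic carbon. Compound 3, like compound 1, lacks that hydroxy, so part or all of this step may be reversed. However, no measured compound carries the 4-(dimethylamino)phenyl group, so its own contribution is unknown and the uncertainty stays wide. A modest move towards a lower number is therefore expected, of about the same size as the measured step or somewhat smaller. The expected change is a 2.9-fold lower number from compound 2 to compound 3 (0.46 log units; beyond the scatter). For compound 3 the estimate is 35000 nM, with an expected range of 10000 nM to 100000 nM.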

Compound 3, half-maximal inhibitory concentration: 12500 nM
The estimate for compound 3 lay 2.8-fold (0.45 log units) above the measured number, and the stated range covers the measured number.
By their numbers in this assay, from the lowest: compounds 3 and 1 (each within the scatter of the next); then compound 2.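

In this assay, replacing the 2-hydroxyphenyl group with 4-(dimethylamino)phenyl on this saturated ring carbon gives an 8.0-fold lower number from compound 2 to compound 3 (0.90 log units; beyond the scatter), so the weak result of compound 2 does not extend to every substituted phenyl group at this position. Measured against the plain phenyl group of compound 1, the 4-(dimethylamino)phenyl group gives a 2.0-fold lower number from compound 1 to compound 3 (0.30 log units; within the scatter), which leaves compound 3 and compound 1 indistinguishable in this assay. The position therefore accepts the 4-(dimethylamino)phenyl group, with 9 heavy atoms against the 7 of 2-hydroxyphenyl, without the penalty seen with compound 2, and among these three compounds only compound 2 stands apart.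

On these data alone, it remains open whether a primary amine, a methoxy group or a carboxylic acid on this phenyl ring would fall with compound 3 and compound 1 or with compound 2. No measurement at hand explains why the 2-hydroxyphenyl group stands apart from the other two groups.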